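Swapping phenyl for prop-1-en-1-yl on a longer chain

The compounds below may be only part of what the source reports. "The series", "measured", "known", "first", "only" and "open" are said of these compounds alone.

Of the compounds shown here, three have been measured in a functional assay on SW-620 cells (Homo sapiens) for cytotoxicity, read by MTT assay, with a stated time of 48 h (a higher number here means a weaker inhibitor, a lower number a stronger inhibitor), and a fourth remains to be tested. Compound 1 `CCCCCCCCNC(=O)[C@@H](NC(=O)/C=C/c1ccccc1)[C@@H](C)O` gives 61400 nM in this assay. Compound 2 `C/C=C/C=C/C(=O)N[C@H](C(=O)NCCCCCCCC)[C@@H](C)O` differs from compound 1 in one place: prop-1-en-1-yl in place of phenyl on a double-bonded chain carbon bound to a double-bonded chain carbon In this assay compound 2 gives 200000 nM, and the step is a 3.3-fold higher number from compound 1 to compound 2 (0.51 log units; beyond the scatter). Compound 3 `CCCCCCCCCCCCCCCCCCNC(=O)[C@@H](NC(=O)/C=C/c1ccccc1)[C@@H](C)O` carries a different core from compound 1, the difference being decyl in place of hydrogen on a saturated chain carbon, eight bonds along the chain from an amide-type nitrogen In this assay compound 3 gives 200000 nM, with the step of a 3.3-fold higher number from compound 1 to compound 3 (0.51 log units; beyond the scatter). Compound 3 and compound 2 stand level at the digits given, so no order can be read between them.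

Compound 4 `C/C=C/C=C/C(=O)N[C@H](C(=O)NCCCCCCCCCCCCCCCCCC)[C@@H](C)O` is the compound still to be measured. It differs from compound 3 by the same change that turned compound 1 into compound 2, at the same place: prop-1-en-1-yl in place of phenyl on a double-bonded chain carbon bound to a double-bonded chain carbon That change, made once before on the shorter core, gave a 3.3-fold higher number from compound 1 to compound 2 (0.51 log units; beyond the scatter). If the same kind of change on the longer core behaves alike, the step from compound 3 to compound 4 is expected to be a 1.5-fold higher number from compound 3 to compound 4 (0.18 log units; within the scatter), and this rests on the step of a 3.3-fold higher number from compound 1 to compound 2 (0.51 log units; beyond the scatter) together with compound 3 already giving 200000 nM, the highest number seen here. Compound 4 is therefore estimated at 300000 nM, within a range from 150000 nM to 700000 nM, with a real chance that the assay reports only a limit.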

Compound 4, half-maximal inhibitory concentration: 200000 nM
The estimate for compound 4 lay 1.5-fold (0.18 log units) above the measured number; the range from low to high includes it.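

In this assay, putting prop-1-en-1-yl in place of phenyl on the longer core gives no change at the digits printed from compound 3 to compound 4 (within the scatter), so the step seen on the shorter core does not carry over to the longer one: the same change on two cores in this assay, a 3.3-fold higher number (0.51 log units; beyond the scatter) from compound 1 to compound 2 and no change at the digits printed (within the scatter) from compound 3 to compound 4, 3.3-fold (0.51 log units) apart, beyond the scatter of two such steps

Read the other way, adding decyl in place of hydrogen on a saturated chain carbon, eight bonds along the chain from an amide-type nitrogen, gives no change at the digits printed from compound 2 to compound 4 (within the scatter), which again differs from the matching step that starts at compound 1: the same change on two cores in this assay, a 3.3-fold higher number (0.51 log units; beyond the scatter) from compound 1 to compound 3 and no change at the digits printed (within the scatter) from compound 2 to compound 4, 3.3-fold (0.51 log units) apart, beyond the scatter of two such steps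

This shows that, for these four compounds, the size of each step depends on which group is already present, but it rests on a single pair of cores and does not show why the steps differ or how the swap would behave on any other core.

The compounds shown leave open how a chain of another length would read in this assay, and whether the swap would produce a step there. Also open, on these data alone, is whether an amine or a carboxylic acid added to the chain would bring the number lower than that of compound 1 at 61400 nM.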